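A few compounds are considered here, and "the series" means these few. Any claim that something is new, unique, unknown or untested is made for them only; others in the source may bear on it.

Within the data shown here, in an ADME assay (liver, Mus musculus) for metabolic stability, using microsomes (a lower number here means that the compound disappears faster, a higher number that the compound lasts longer), compound 2 `CS(=O)(=O)c1cnc(O[C@H]2CC[C@H](OC3CCN(CC4(C(F)(F)F)CC4)CC3)CC2)cn1` gives 0.617 h, the only exact number so far. Compound 1 `CC(C)OC(=O)N1CCC(O[C@H]2CC[C@H](Oc3cnc(S(C)(=O)=O)cn3)CC2)CC1` gives > 1 h, which is a limit of the assay and not a number. Compound 3 `CC(C)c1noc(CN2CCC(O[C@H]3CC[C@H](Oc4cnc(S(C)(=O)=O)cn4)CC3)CC2)n1` differs from compound 2 by 3-isopropyl-1,2,4-oxadiazol-5-yl in place of 1-(trifluoromethyl)cyclopropyl on a saturated chain carbon bound to an amine nitrogen in a ring. Among the measured compounds shown here, the only measured guide is an at least 1.6-fold lower number from compound 1 to compound 2 (0.20 log units; that floor lies within the scatter), a change of group on the same amine nitrogen in a ring, so no shift beyond the scatter is expected in this assay. The expected change is a 1.2-fold lower number from compound 2 to compound 3 (0.09 log units; within the scatter). For compound 3 the estimated half-life is 0.5 h, with an expected range of 0.2 h to 1 h.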

Compound 3, half-life: > 1 h
Compound 3 ended at the assay's limit; the forecaster's own chance of this, stated with the estimate: 15%; middle value at least 2.0-fold (0.30 log units) away from the limit.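

In this assay, 3-isopropyl-1,2,4-oxadiazol-5-yl in place of 1-(trifluoromethyl)cyclopropyl on a saturated chain carbon bound to an amine nitrogen in a ring gives an at least 1.6-fold higher number from compound 2 to compound 3 (0.20 log units; that floor lies within the scatter). On these data alone, that step rests on a limit of the assay, so its true size stays unknown. The step between compound 1 and compound 3 cannot be read, and the two cannot be ordered: the limit of > 1 h in this assay, at which 2 of the 3 values shown sit.

As far as these compounds go, whether a phenyl or a pyridine ring on that chain carbon would also reach the limit remains open.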